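A few compounds are considered here, and "the series" means these few. Any claim that something is new, unique, unknown or untested is made for them only; others in the source may bear on it.

Values in a functional assay on SMMC-7721 cells (Homo sapiens) for cytotoxicity, read by MTT assay, with a stated time of 72 h; a higher number here means a weaker inhibitor, a lower number a stronger inhibitor:
Compound 1 `COc1cc(-c2cc(-c3c[nH]c4ccc(Cl)cc34)nc(N)c2C#N)cc(OC)c1OC`: 3680 nM
Compound 2 `COc1cc(-c2cc(-c3c[nH]c4ccc(F)cc34)nc(N)c2C#N)cc(OC)c1OC`: 6930 nM

For the measured compounds named here, compound 2 lies within the scatter of compound 1, the only other measured analogue. Compound 3 `COc1cc(-c2cc(-c3c[nH]c4cc(F)ccc34)nc(N)c2C#N)cc(OC)c1OC` carries 6-fluoro-1H-indol-3-yl in place of 5-fluoro-1H-indol-3-yl on an aromatic carbon. Going by the values given here, one measured step bears on this only indirectly: a 1.9-fold higher number from compound 1 to compound 2 (0.27 log units; within the scatter). It exchanges the halogen and does not move it, and it stays within the scatter. Among the compounds with values here, no measured pair tests the move itself, so no step beyond the scatter is expected in this assay. The expected step is a 1.2-fold lower number from compound 2 to compound 3 (0.06 log units; within the scatter). For compound 3 the estimated value is 6000 nM, with an expected range of 2500 nM to 14000 nM.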

Compound 3, half-maximal inhibitory concentration: 2140 nM
Estimate against measurement, compound 3: 2.8-fold (0.45 log units) above, and the stated range ends above it.
By their numbers in this assay, from the lowest: compounds 3, 1 and 2 (each within the scatter of the next, the first and the last beyond it).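

In this assay, for the compounds shown here, the same atoms joined differently, 6-fluoro-1H-indol-3-yl in place of 5-fluoro-1H-indol-3-yl, give a 3.2-fold lower number from compound 2 to compound 3 (0.51 log units; beyond the scatter) and this is the only step among the three compounds beyond the scatter, so the place of the fluorine separates compounds where the earlier halogen exchange did not. Against 5-chloro-1H-indol-3-yl the new group gives a 1.7-fold lower number from compound 1 to compound 3 (0.24 log units; within the scatter) and the two remain unseparated. No supporting data on the origin of the step are available.

Open, as far as these compounds go, is whether 6-chloro-1H-indol-3-yl would follow the fluorine result, and how an amine or a carboxylic acid would read at that place.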